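This account rests on a few compounds, and the source may have more. Where it says the series, first, only, none or still open, it means among the compounds named here.

Compound 1 `CNC(=O)c1cc(Oc2ccc(NC(=O)c3cc(-c4ccc(OC)cc4)ncn3)cc2F)ccn1` was tested in a functional assay on PC-3 cells (Homo sapiens) for cytotoxicity, read by MTT assay, with a stated time of 72 h (on this read-out lower numbers stand for stronger inhibition and higher numbers for weaker inhibition), together with two companions. In this assay compound 1 gives 56200 nM, which is the highest of the two numbers that came out as numbers, so it is the weaker of the two measured compounds. Compound 3 `CNC(=O)c1cc(Oc2ccc(NC(=O)c3nccc(-c4cccc(Cl)c4)n3)cc2)ccn1` gives 20800 nM in this assay, a lower number than compound 1 and one that lies beyond the usual scatter of repeated measurements. Compound 2 `CNC(=O)c1cc(Oc2ccc(NC(=O)c3cc(-c4ccc(C)cc4)ncn3)cc2)ccn1` yields no number in this assay, only a limit, > 100000 nM, which is the limit of > 100000 nM in this assay, at which 1 of the 3 values shown sits.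

Compound 4 `CNC(=O)c1cc(Oc2ccc(NC(=O)c3cc(-c4ccc(Br)cc4)ncn3)cc2F)ccn1` has not yet been measured. It differs from compound 1 in one spot: bromo in place of methoxy on an aromatic carbon. Among the compounds with values here, none of the measured compounds shows this same change, so there is no measured step to lean on, and the expectation rests on compound 1 alone. The step from compound 1 to compound 4 is expected to be small, a 1.2-fold lower number from compound 1 to compound 4 (0.10 log units; within the scatter), with no clear direction beyond the scatter. Compound 4 is therefore estimated at about 45000 nM in this assay, with a range from 12000 nM to 150000 nM that also allows for a value reported only as a limit.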

Compound 4, half-maximal inhibitory concentration: > 100000 nM
Compound 4: only a limit was reported (the forecaster's own chance of this, stated with the estimate: 30%); at least 2.2-fold (0.34 log units) between middle value and limit.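

The 4-methoxyphenyl to 4-bromophenyl change now has a measured step in this assay: an at least 1.7-fold higher number from compound 1 to compound 4 (0.25 log units; that floor lies within the scatter). Only the lower bound of this step is known, and it does not clear the scatter, so the result shows no gain from bromo at this position but does not show how much is lost, or firmly that anything is lost. The result for compound 4 is a limit rather than a number, and it means that the methoxy of compound 1 is not replaced here by a group giving a lower number, while the limit itself now recurs in the set: the limit of > 100000 nM in this assay, at which 2 of the 4 values shown sit.

Going by these compounds, the true value of compound 4 lies somewhere beyond its limit, so the size of the step stays unknown, and the comparison cannot say whether methoxy and bromo truly differ at this position. Also open, on these data alone, is how an amine or a hydroxyl group on the same aromatic carbon would read in this assay, and whether any group there could bring the number well under that of compound 1, 56200 nM.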